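Chain homologation on the piperazine side chain of compound 1

The compounds below may be only part of what the source reports. "The series", "measured", "known", "first", "only" and "open" are said of these compounds alone.

Compound 1 `COc1cc(C)c(S(=O)(=O)N(C)CCOCC(=O)N2CCN(CCN(C)C)CC2)c(C)c1` gives 106 nM in an assay on HEK293 cells for displacement of a labelled ligand from B1 bradykinin receptor (Homo sapiens), read by scintillation counting; a higher number here means a weaker inhibitor, a lower number a stronger inhibitor. Compound 3 `CN(Cc1ccc(C2=NCCN2)cc1)C(=O)COCCN(C)S(=O)(=O)c1ccc(OC(F)(F)F)cc1`, a different sulfonamide bearing an amidine-type terminus, gives 85 nM in this assay, a value within the scatter of compound 1, so the two are not separated. Compound 2 `COc1cc(C)c(S(=O)(=O)N(C)CCOCC(=O)N2CCC(N3CCN(C(C)C)CC3)CC2)c(C)c1`, which carries a piperidinyl-piperazine in place of the aminoethyl piperazine, gives 3.8 nM, far below compound 1. Compound 4 `COc1cc(C)c(S(=O)(=O)N(C)CCOCC(=O)N2CCN(CCCN(C)C)CC2)c(C)c1` has not been measured; it differs from compound 1 by (dimethylamino)methyl in place of dimethylamino on a saturated chain carbon, two bonds along the chain from an amine nitrogen in a ring. Among the measured compounds shown here, no measured pair shows the effect of lengthening this chain, so no direction can be drawn from the data. For compound 4 a step of a 1.0-fold higher number from compound 1 to compound 4 (0.02 log units; within the scatter) is expected, not beyond the scatter. Compound 4 is thus estimated at 110 nM, between 40 nM and 300 nM.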

Compound 4, inhibition constant: 5.8 nM
Compound 4: the middle estimate sits 19-fold (1.28 log units) above what was measured; the whole stated range lies above it.
By their numbers in this assay, from the lowest: compounds 2 and 4 (each within the scatter of the next); then compounds 3 and 1 (each within the scatter of the next).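

In this assay the length of this chain matters: (dimethylamino)methyl in place of dimethylamino, on a saturated chain carbon, gives an 18-fold lower number from compound 1 to compound 4 (1.26 log units; beyond the scatter). Among the compounds shown here, this is the first measured pair to isolate a change at this position, and the whole step comes with one added chain carbon while the terminal dimethylamino group stays in place. Nothing at hand explains the step.

As far as these compounds go, whether a longer chain, such as 4-(dimethylamino)butyl, keeps this level remains open. So does whether a pyrrolidine or a primary amine can replace the terminal dimethylamino on the longer chain.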